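Shortening the side chain of compound 3

The source may hold more compounds than are shown below. What is called first, only, known or untested is meant among the compounds shown, and "the series" means these compounds.

Three compounds share one core and differ only in the side chain on the saturated chain carbon. Compound 1 `CC[C@H](C)[C@H](NC(=O)CN(c1nc(Cl)nc2[nH]cnc12)C1CC1)C(=O)O` gives 27.4% in a functional assay on the whole organism (Tail, strain ICR) with Mus musculus as the target, in the tail flick test, with a stated time of 90 min, at a dose of 25 umol/kg by the oral route; on this read-out lower numbers stand for a weaker effect and higher numbers for a stronger effect at the one dose given; compound 2 `O=C(O)C[C@H](NC(=O)CN(c1nc(Cl)nc2[nH]cnc12)C1CC1)C(=O)O` gives 25.1% there, and compound 3 `NC(=O)CC[C@H](NC(=O)CN(c1nc(Cl)nc2[nH]cnc12)C1CC1)C(=O)O` gives 41.1%. Compound 3 stands highest of the three, with the step of a number 13.7 percentage points higher from compound 1 to compound 3 (beyond the scatter) and the step of a number 16 percentage points higher from compound 2 to compound 3 (beyond the scatter), both beyond the usual scatter, while the step of a number 2.3 percentage points lower from compound 1 to compound 2 (within the scatter) lies within it.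

Compound 4 `C[C@H](NC(=O)CN(c1nc(Cl)nc2[nH]cnc12)C1CC1)C(=O)O` is the next step: hydrogen in place of carbamoylmethyl on a saturated chain carbon, two bonds along the chain from an amide-type nitrogen and a carbonyl carbon. The two steps that bear on this change are those leading to compound 3, since both add the carbamoyl-bearing chain that compound 4 lacks, and each raised the read-out by a modest amount. Compound 4 is therefore expected to fall back toward the level of compound 1 and compound 2, a step estimated as a number 14.1 percentage points lower from compound 3 to compound 4 (beyond the scatter). The estimate for compound 4 is 27%, with a range from 14% to 40%.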

Compound 4, a percentage reported as activity, at one dose (the size of the read-out at that dose, not a potency): 43.5%
For compound 4 the middle estimate is 16.5 percentage points below the measured one; measured number above the stated range.
By their numbers in this assay, from the lowest: compounds 2 and 1 (each within the scatter of the next); then compounds 3 and 4 (each within the scatter of the next).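

In this assay, cutting the 2-carbamoylethyl chain back to methyl changes nothing that can be told from the scatter, with a number 2.4 percentage points higher from compound 3 to compound 4 (within the scatter), so the carbamoyl end of that chain is not needed to reach this level. The methyl compound also separates from the other two side chains, with a number 16.1 percentage points higher from compound 1 to compound 4 (beyond the scatter) and a number 18.4 percentage points higher from compound 2 to compound 4 (beyond the scatter), so side-chain size alone does not order the series: the large 2-carbamoylethyl of compound 3 sits level with methyl, while sec-butyl and carboxymethyl give lower numbers. Nothing available here explains why these side chains differ.

The compounds shown leave open whether a side chain with an amine at its end, or a hydroxymethyl group, would stay at the level of methyl or fall to that of carboxymethyl. They also leave open whether hydrogen alone on this carbon, with no methyl at all, would keep the read-out there.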